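Methoxy for Fluoro: a Step Taken Near the Solubility Limit

The compounds below may be only part of what the source reports. "The series", "measured", "known", "first", "only" and "open" are said of these compounds alone.

Compound 1 `Cc1cc(NCc2ccccn2)n2ncc(-c3ccc(F)cc3)c2n1`: < 5000 nM
Compound 2 `Cc1cc(NCc2ncccn2)n2nc(C)c(-c3ccccc3)c2n1`: 37900 nM

In a physicochemical assay for solubility, read by HPLC, using the shake flask method, measured as kinetic solubility, with a stated time of 2 h, at pH 7.4 (on this read-out higher numbers stand for higher solubility and lower numbers for lower solubility), compound 1 `Cc1cc(NCc2ccccn2)n2ncc(-c3ccc(F)cc3)c2n1` gives < 5000 nM, which is a limit of the assay and not a number, as the limit of < 5000 nM in this assay, at which 1 of the 2 values shown sits, records. In this assay compound 2 `Cc1cc(NCc2ncccn2)n2nc(C)c(-c3ccccc3)c2n1` gives 37900 nM. Among the measured compounds shown here, compound 1 and compound 2 differ in more than one place, so no single step joins them and the two values can only be set side by side.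

Compound 3 `COc1ccc(-c2cnn3c(NCc4ccccn4)cc(C)nc23)cc1` differs from compound 1 by methoxy in place of fluoro on an aromatic carbon. For the measured compounds named here, no measured pair covers this change, so the direction is unknown, and the step is expected to be a step that the limit leaves unreadable from compound 1 to compound 3, no larger than the usual scatter, with a real chance that compound 3 again returns only a limit. Compound 3 is therefore estimated at 4000 nM, within a range from 1000 nM to 15000 nM.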

Compound 3, solubility: < 5000 nM
Compound 3 ended at the assay's limit; the forecaster's own chance of this, stated with the estimate: 55%; the middle value lies beyond the limit too.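

In this assay compound 3, like compound 1, returns a limit and not a number, so no step can be read between them: the limit of < 5000 nM in this assay, at which 2 of the 3 values shown sit.

The compounds shown leave open whether methoxy in place of fluoro shifts this read-out at all, and in which direction.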